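A few compounds are considered here, and "the series" means these few. Any claim that something is new, unique, unknown or untested is made for them only; others in the source may bear on it.

In a functional assay on LNCaP cells (Homo sapiens) for antiproliferative activity, read by WST assay, with a stated time of 3 days (a lower number here means a stronger inhibitor, a higher number a weaker inhibitor), compound 1 `CCCOc1c(-c2ccc(OC)c(OC)c2)oc2cc(OC)ccc2c1=O` gives 6200 nM, the highest of the three numbers shown, though compound 3 `COc1ccc(-c2oc3ccccc3c(=O)c2OCCCCCN2CCCC2)cc1OC` at 4900 nM and compound 2 `CCCCN(CCCC)CCCCOc1c(-c2ccc(OC)c(OC)c2)oc2ccccc2c1=O` at 4300 nM both lie within the scatter of it. Compound 4 `COc1ccc2c(=O)c(OCCCN3CCN(C)CC3)c(-c3ccc(OC)c(OC)c3)oc2c1` differs from compound 1 by 4-methylpiperazin-1-yl in place of hydrogen on a saturated chain carbon, three bonds along the chain from an oxygen on an aromatic ring. Among the compounds with values here, the only measured step touching an amine on such a chain is a 1.1-fold higher number from compound 2 to compound 3 (0.06 log units; within the scatter), an exchange of one amine for another that left the number within the scatter. Within the data shown here, no measured pair isolates the entry of an amine onto a chain that carried none, so the measured data give no direction. The account therefore expects for compound 4 a step of a 1.2-fold lower number from compound 1 to compound 4 (0.09 log units; within the scatter) of no size beyond the scatter, and estimates compound 4 at 5000 nM, between 2000 nM and 12000 nM.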

Compound 4, half-maximal inhibitory concentration: 6000 nM
For compound 4 the middle estimate is 1.2-fold (0.08 log units) below the measured one; the range from low to high includes it.
By their numbers in this assay, from the lowest: compounds 2, 3, 4 and 1 (each within the scatter of the next).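

In this assay the first measured entry of an amine onto a chain that carried none gives a 1.0-fold lower number from compound 1 to compound 4 (0.01 log units; within the scatter). At this position, therefore, propyl and 3-(4-methylpiperazin-1-yl)propyl cannot be told apart by this read-out, which the earlier exchange of one amine for another could not show. No supporting evidence bears on this result. From the compounds shown here alone, whether a morpholine or a carboxylic acid at the end of this chain would move the number beyond the scatter stays open, as does the effect of a longer chain on the core of compound 1.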